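Propyl to Phenyl on the Ester of a Diterpene Diol

This account rests on a few compounds, and the source may have more. Where it says the series, first, only, none or still open, it means among the compounds named here.

Measured compounds:
Compound 1, `CCC(=O)OC/C=C(\C)C[C@@H](O)[C@@]1(C)[C@H](C)CC=C2[C@@H]1CCCC2(C)C`, in a functional assay on U-937 cells (Homo sapiens) for cytotoxicity, read by MTT assay, with a stated time of 72 h (on this read-out lower numbers stand for stronger inhibition and higher numbers for weaker inhibition), gives 24700 nM.
Compound 2, `CCCC(=O)OC/C=C(\C)C[C@@H](O)[C@@]1(C)[C@H](C)CC=C2[C@@H]1CCCC2(C)C`, in this assay gives only > 30000 nM, which is a limit of the assay and not a number.

Compound 2 stands at the limit, (the limit of > 30000 nM in this assay, at which 1 of the 2 values shown sits), so its true value is not fixed by the numbers at hand. Compound 3, `C/C(=C\COC(=O)c1ccccc1)C[C@@H](O)[C@@]1(C)[C@H](C)CC=C2[C@@H]1CCCC2(C)C`, carries a change at the ester: phenyl in place of propyl on a carbonyl carbon. Among the compounds with values here, the one measured step that touches this region is an at least 1.2-fold higher number from compound 1 to compound 2 (0.08 log units; that floor lies within the scatter), an enlargement of the saturated chain on the carbonyl side that produced no resolved gain in cytotoxicity. Within the data shown here, the propyl-to-phenyl change is larger and of a different kind, and no measured step covers it, so the expectation rests on the flat behaviour seen so far. Compound 3 is therefore expected to sit near where compound 2 stands, with a number no higher from compound 2 to compound 3 (the limit leaves the size open) as the estimated step. For compound 3 the estimate in this assay is 30000 nM, with a range from 9000 nM to 100000 nM, and a real chance that only a limit is reported again.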

Compound 3, half-maximal inhibitory concentration: > 30000 nM
Compound 3: no number, only a limit; the forecaster's own chance of this, stated with the estimate: 55%; the middle value lies on the limit itself.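

In this assay compound 3 gives > 30000 nM, which is a limit of the assay and not a number. Within the data shown here, measured against the only compound here with a real number, the swap of ethyl for phenyl on the carbonyl carbon gives an at least 1.2-fold higher number from compound 1 to compound 3 (0.08 log units; that floor lies within the scatter), so an aromatic ring at the ester, like the longer saturated chain before it, brings no resolved gain in cytotoxicity, and any loss has no readable size. The step between the two limits cannot be read, so propyl and phenyl at this ester cannot be ranked against each other: the limit of > 30000 nM in this assay, at which 2 of the 3 values shown sit.

Going by these compounds, it remains open whether a smaller acetyl group, or a free hydroxyl with no ester at all, would move the value of compound 1, 24700 nM, clearly in either direction. Also open, on these data alone, is whether a benzoyl ring carrying an amine or a carboxylic acid would return a true number in this cell assay, which would show whether the ester position can respond at all.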